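Trimethoxyphenyl pyrazole chalcones: removing one methoxy group

A few compounds are considered here, and "the series" means these few. Any claim that something is new, unique, unknown or untested is made for them only; others in the source may bear on it.

Measured so far:
compound 1, `COc1cc(-c2cc(/C=C/C(=O)c3ccc(N)cc3)[nH]n2)cc(OC)c1OC` — > 100000 nM
compound 2, `COc1cc(-c2cc(/C=C/C(=O)c3ccc(Cl)c(Cl)c3)[nH]n2)cc(OC)c1OC` — 75900 nM

Compound 1 stands at a limit of the assay. In a functional assay on HOP-92 cells (Homo sapiens) for inhibition, read by sulforhodamine B assay, with a stated time of 48 h (a lower number here means that less compound is tolerated, a higher number that more compound is tolerated), compound 1 gives > 100000 nM, which is a limit and not a number (the limit of > 100000 nM in this assay, at which 1 of the 2 values shown sits). Compound 2 sits within the measured range; in this assay compound 2 gives 75900 nM. Within the data shown here, the only measured step, an at least 1.3-fold lower number from compound 1 to compound 2 (0.11 log units; that floor lies within the scatter), changes the aryl ketone end and so says nothing direct about the methoxy-bearing ring.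

Compound 3, `COc1ccc(-c2cc(/C=C/C(=O)c3ccc(N)cc3)[nH]n2)cc1OC`, differs from compound 1 by hydrogen in place of methoxy on an aromatic carbon. Among the measured compounds shown here, no measured step covers a change of that kind, so no step beyond the scatter is expected; compound 3 is estimated at 150000 nM (range 60000 nM to 400000 nM), which in this assay means an expected step that the limit leaves unreadable from compound 1 to compound 3, with a real chance that only a limit is again reported.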

Compound 3, concentration lethal to 50% of the cells: 63900 nM
Estimate against measurement, compound 3: 2.3-fold (0.37 log units) above, and the stated range covers the measured number.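

In this assay compound 3 gives 63900 nM with hydrogen in place of methoxy on this aromatic carbon, so this change yields a real number for the 4-aminophenyl ketone. The step is an at least 1.5-fold lower number from compound 1 to compound 3 (0.19 log units; that floor lies within the scatter) and so shows no change beyond the scatter at this position. Its full size stays unread: the limit of > 100000 nM in this assay, at which 1 of the 3 values shown sits.

Open, on these data alone, is whether the same removal of methoxy gives a readable step with the 3,4-dichlorophenyl ketone of compound 2. Also open, as far as these compounds go, is whether a hydroxy group or fluorine on this carbon moves the number beyond the scatter.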